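Series notes: fluorine pattern on the aryl ring

The source may hold more compounds than are shown below. What is called first, only, known or untested is meant among the compounds shown, and "the series" means these compounds.

Measured compounds:
Compound 1 `CCc1ccc(-c2nnc(COc3cnn(C(C)(C)C)c(=O)c3Cl)o2)cc1` gives 3.52 in a physicochemical assay for lipophilicity; a lower number here means a more polar compound, a higher number a more lipophilic compound.
Compound 2 `CC(C)(C)n1ncc(OCc2nnc(-c3cc(F)c(F)cc3F)o2)c(Cl)c1=O` gives 2.96.
Compound 3 `CC(C)(C)n1ncc(OCc2nnc(-c3c(F)cccc3F)o2)c(Cl)c1=O` gives 2.75.

Compound 2 stands second highest of the three numbers; compound 1 sits a number 0.56 log units lower from compound 1 to compound 2 (beyond the scatter) and compound 3 sits a number 0.21 log units lower from compound 2 to compound 3 (within the scatter), the latter within the scatter.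

Compound 4 `CC(C)(C)n1ncc(OCc2nnc(-c3cc(F)c(F)c(F)c3F)o2)c(Cl)c1=O` has not been measured in this assay. It differs from compound 2 as follows: fluoro in place of hydrogen on an aromatic carbon.

The steps with a bearing on this change are those that alter the fluorine count on the aryl ring. The step of a number 0.21 log units lower from compound 2 to compound 3 (within the scatter) removes one fluorine and stays within the scatter. The larger steps, a number 0.56 log units lower from compound 1 to compound 2 (beyond the scatter) and a number 0.77 log units lower from compound 1 to compound 3 (beyond the scatter), replace 4-ethylphenyl altogether and so say little about a single fluoro for hydrogen exchange. One added fluoro is therefore expected to shift this assay at most modestly upward, likely within the scatter.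

Compound 4 is estimated at 3.15, with a range of 2.85 to 3.45, which would mean an expected step of a number 0.19 log units higher from compound 2 to compound 4 (within the scatter).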

Compound 4, partition coefficient: 3.18
Beside the measured number, compound 4's estimate is 0.03 log units below it, and the stated range covers the measured number.
By their numbers in this assay, from the lowest: compounds 3, 2 and 4 (each within the scatter of the next, the first and the last beyond it); then compound 1.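

Unlike the steps among compounds 1, 2 and 3, each of which replaces one whole aryl group with another, this change isolates a single fluoro in place of hydrogen. In this assay, placing that fluoro on the aromatic carbon ortho to two fluoro groups and meta to a large group gives a number 0.22 log units higher from compound 2 to compound 4 (within the scatter), so compound 4 cannot be told apart from compound 2 at this position. No measurement shown accounts for the size of this step.

As far as these compounds go, only fluoro and hydrogen are compared at this position, so it remains open whether a larger or charged group there, such as a methoxy group, an amine or a carboxylic acid, would give a step beyond the scatter. One exchange also leaves open whether the same fluoro for hydrogen change would read alike at the other carbons of this ring.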